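Amide nitrogen substituent changes on the shared core

The source may report more compounds than this note shows. Statements on the series, on what has been measured and on what is new or still open speak of the compounds shown alone.

Measured so far in a functional assay on MCF7 cells (Homo sapiens) for inhibition; on this read-out lower numbers stand for stronger inhibition of growth and higher numbers for weaker inhibition of growth:
compound 1 `Cc1cccc(NC(=O)COc2ccc(/C=C3\SC(=O)NC3=O)cc2)n1` gives 28300 nM
compound 2 `O=C(COc1ccc(/C=C2\SC(=O)NC2=O)cc1)Nc1ccc(Cl)cc1` gives 51100 nM
compound 3 `Cc1cc(Br)ccc1NC(=O)COc1ccc(/C=C2\SC(=O)NC2=O)cc1` gives 66800 nM

Compound 1 carries the lowest of the three numbers in this assay; its nearest neighbour is compound 2, and a 1.8-fold higher number from compound 1 to compound 2 (0.26 log units; within the scatter) stays within the scatter. Among the measured compounds shown here, the only step beyond the scatter is a 2.4-fold higher number from compound 1 to compound 3 (0.37 log units; beyond the scatter), a modest rise. Between the two aryl amides themselves a 1.3-fold higher number from compound 2 to compound 3 (0.12 log units; within the scatter), again within the scatter.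

Compound 4 `O=C(COc1ccc(/C=C2\SC(=O)NC2=O)cc1)Nc1c(Cl)cccc1Cl` is the next member. Relative to compound 1 the change is 2,6-dichlorophenyl in place of 6-methylpyridin-2-yl on an amide-type nitrogen. Both measured steps away from compound 1 replace the 6-methylpyridin-2-yl on the amide-type nitrogen with a carbon-only aromatic ring, and both raised the number: one within the scatter, one modestly beyond it. The 2,6-dichlorophenyl of compound 4 is a third such carbon-only ring, so the expectation in this assay is a step of similar size and direction, a mild rise that may or may not exceed the scatter.

Compound 4 is therefore estimated at 50000 nM, with a range from 25000 nM to 100000 nM. This estimate corresponds to a 1.8-fold higher number from compound 1 to compound 4 (0.25 log units; within the scatter), in line with the two measured aryl replacements from compound 1.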

Compound 4, concentration for 50% growth inhibition: 61700 nM
Compound 4: middle estimate off by 1.2-fold (0.09 log units), on the low side; low and high end bracket the measured number.
By their numbers in this assay, from the lowest: compounds 1, 2, 4 and 3 (each within the scatter of the next, the first and the last beyond it).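

In this assay there is a 2.2-fold higher number from compound 1 to compound 4 (0.34 log units; beyond the scatter) and this is the second replacement of the 6-methylpyridin-2-yl to lie beyond the scatter, so two of the three carbon-only rings now stand clear of compound 1 while the 4-chlorophenyl of compound 2 does not. The 2,6-dichlorophenyl adds no separation among those carbon-only rings: a 1.2-fold higher number from compound 2 to compound 4 (0.08 log units; within the scatter) and a 1.1-fold lower number from compound 3 to compound 4 (0.03 log units; within the scatter) both stay within the scatter, so the 4-chlorophenyl, 4-bromo-2-methylphenyl and 2,6-dichlorophenyl amides read alike in this assay despite their different halogen and methyl substitution. No measurement is available that bears on why this replacement gives this result.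

Still open, going by these compounds, is whether the lower number of compound 1 goes with the ring nitrogen of the 6-methylpyridin-2-yl, with its methyl, or with the two together, a question that an unsubstituted pyridin-2-yl or a plain phenyl on the amide-type nitrogen would address. Also open, on these data alone, is how a non-aromatic group at this place, such as a cyclohexyl or a longer chain ending in an amine or a carboxylic acid, would compare with these aromatic rings.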